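Methyl for trifluoromethyl: notes on compound 4

The compounds below may be only part of what the source reports. "The series", "measured", "known", "first", "only" and "open" are said of these compounds alone.

Measured compounds in a functional assay on T47D cells (Homo sapiens) for cytotoxicity, read by MTT assay, with a stated time of 2 days; on this read-out higher numbers stand for weaker inhibition and lower numbers for stronger inhibition:
- compound 1, `Cc1ccc2c(=O)[nH]c(-c3ccccc3F)nc2c1`: > 50000 nM
- compound 2, `Cc1ccc2nc(-c3ccccc3C(F)(F)F)[nH]c(=O)c2c1`: > 50000 nM
- compound 3, `COc1cccc(-c2nc3ccc(N4CCCCC4)cc3c(=O)[nH]2)c1OC`: 10400 nM

In this assay compound 1 gives no number, only a limit, > 50000 nM. Compound 2 likewise gives only a limit, > 50000 nM. Among the compounds with values here, compound 3 is the single compound of the three with a numerical value, 10400 nM. Compound 2 therefore stands at the limit of > 50000 nM in this assay, at which 2 of the 3 values shown sit; one further value shown is also a limit, so nothing can be said about order between compound 1 and compound 2. Within the data shown here, no pair of measured compounds differs in a single place, so no measured step is available.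

Compound 4, `Cc1ccc2nc(-c3ccccc3C)[nH]c(=O)c2c1`, is not yet measured. It differs from compound 2 by methyl in place of trifluoromethyl on an aromatic carbon. Among the measured compounds shown here, with no measured step to lean on, and compound 2 sitting at a limit rather than a number, the expectation is that the change from compound 2 to compound 4 yields no step beyond the usual scatter, and that compound 4 will also most likely return only a limit. Compound 4 is estimated at 50000 nM, with a range from 15000 nM to 200000 nM. The estimated step of a number no higher from compound 2 to compound 4 (the limit leaves the size open) is accordingly expected to be essentially flat.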

Compound 4, half-maximal inhibitory concentration: > 50000 nM
Compound 4: only a limit was reported (the forecaster's own chance of this, stated with the estimate: 80%); the middle value sits exactly at the limit.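

Compound 4, with methyl in place of trifluoromethyl, gives only a limit in this assay, as compound 2 does, so no step can be read between the two: the limit of > 50000 nM in this assay, at which 3 of the 4 values shown sit.

The compounds shown leave open whether methyl and trifluoromethyl at this place differ at all in this assay, since neither compound has a numerical value.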